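Amino for methoxy on a shared scaffold: a second look

The source may report more compounds than this note shows. Statements on the series, on what has been measured and on what is new or still open speak of the compounds shown alone.

The starting point is compound 1 `COc1ccc(-c2cc3ccccc3c(-c3cccc(OC)c3)n2)cc1`, which in an assay on isolated protein for inhibition of DNA topoisomerase 1 (Homo sapiens), with a stated time of 30 min, tested at 100 uM (a higher number here means a stronger effect of the compound at the concentration tested, a lower number a weaker effect), gives 43.2%. For the measured compounds named here, compound 2 `COc1ccc(-c2cc3ccccc3c(-c3cccc(N)c3)n2)cc1` carries the single change (amino in place of methoxy on an aromatic carbon), and in this assay compound 2 gives 0%. The step of a number 43.2 percentage points lower from compound 1 to compound 2 (beyond the scatter) is therefore the only measured effect of this change, and it is a large loss.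

Compound 3 `COc1cccc(-c2nc(-c3ccc(OC)c(OC)c3)cc3cc(C)ccc23)c1` is built on a different core, and the difference between the two cores is not broken down here. In this assay compound 3 gives 2.9%, a value that sits close to that of compound 2 and well under that of compound 1.

Compound 4 `COc1ccc(-c2cc3cc(C)ccc3c(-c3cccc(N)c3)n2)cc1OC` is not yet measured. It stands to compound 3 as compound 2 stands to compound 1: the change amino in place of methoxy on an aromatic carbon is the same change, at the same kind of place, seen a second time in this set. Because compound 3 already gives 2.9%, there is little room left for a loss of the size seen in a number 43.2 percentage points lower from compound 1 to compound 2 (beyond the scatter), so the step of a number 1.9 percentage points lower from compound 3 to compound 4 (within the scatter) is expected to be small, with the read-out staying near the bottom of the range. Compound 4 is accordingly estimated at 1%, within a range from 0% to 10%.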

Compound 4, a percentage reported as inhibition, at one concentration (the size of the read-out at that concentration, not a potency): 7.2%
Compound 4: middle estimate off by 6.2 percentage points, on the low side; the measured number falls inside the stated range.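

Set beside the earlier step, the second reading of amino in place of methoxy in this assay does not repeat the first: the same change on two cores in this assay, a number 43.2 percentage points lower (beyond the scatter) from compound 1 to compound 2 and a number 4.3 percentage points higher (within the scatter) from compound 3 to compound 4, 47.5 percentage points apart, beyond the scatter of two such steps On the core of compound 3 the step reads a number 4.3 percentage points higher from compound 3 to compound 4 (within the scatter), so the large loss seen on the core of compound 1 does not carry over to this second core as a measured loss. This does not show that the change is harmless on the second core or that the two cores respond to it in opposite ways, since compound 3 already gives 2.9%, which leaves almost no room for a loss to appear, and two pairs at a single concentration cannot establish a rule for the series.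

The compounds shown leave open which part of the difference between the two cores goes with the difference between the two steps, and whether the amino change would cost as much on a core that starts from a clearly higher read-out than compound 3. They also leave open how other groups at this place on the phenyl ring would read in this assay, for example a hydroxyl, a dimethylamino group or an acetamide.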